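A 4-Methylphenyl Variant of Compound 1 in Lung Cells

The source may report more compounds than this note shows. Statements on the series, on what has been measured and on what is new or still open speak of the compounds shown alone.

Measured compounds:
compound 1, `CCOC(=O)C1=Cc2ccccc2OC1(OCc1cn(-c2ccc(F)c([N+](=O)[O-])c2)nn1)C(F)(F)F`: 11900 nM
compound 2, `O=C(O)C1=Cc2ccccc2OC1(OCc1cc(-c2ccc3ccccc3c2)no1)C(F)(F)F`: > 150000 nM
compound 3, `O=C(O)C1=Cc2ccccc2OC1(OCc1cc(-c2cccc(C(F)(F)F)c2)no1)C(F)(F)F`: > 150000 nM

For the measured compounds named here, in a functional assay on A549 cells (Homo sapiens) for inhibition, read by MTT assay, with a stated time of 24 h (on this read-out lower numbers stand for stronger inhibition and higher numbers for weaker inhibition), compound 1 gives 11900 nM, the only number among the three values shown. For compound 2 the value > 150000 nM is a limit of the assay and not a number. For compound 3 the value > 150000 nM is likewise a limit. Going by the values given here, the step that the two limits leave unreadable from compound 2 to compound 3 is thus unreadable, and the limit of > 150000 nM in this assay, at which 2 of the 3 values shown sit, is the only evidence the measured pairs offer.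

Compound 4, `CCOC(=O)C1=Cc2ccccc2OC1(OCc1cn(-c2ccc(C)cc2)nn1)C(F)(F)F`, differs from compound 1 by 4-methylphenyl in place of 4-fluoro-3-nitrophenyl on an aromatic nitrogen. Among the compounds with values here, no measured step touches this change, and compounds 2 and 3 differ from compound 1 in other parts of the structure as well, so they give no reading of it. Compound 4 is therefore expected to show a step of a 1.3-fold higher number from compound 1 to compound 4 (0.10 log units; within the scatter) that stays within the scatter. The estimate for compound 4 is 15000 nM, expected between 4000 nM and 60000 nM.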

Compound 4, half-maximal inhibitory concentration: 19700 nM
Beside the measured number, compound 4's estimate is 1.3-fold (0.12 log units) below it, within the range that was stated.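

Placing 4-methylphenyl in place of 4-fluoro-3-nitrophenyl on the aromatic nitrogen gives a 1.7-fold higher number from compound 1 to compound 4 (0.22 log units; within the scatter) in this assay, and this is the only step among the compounds shown that can be read. It shows that this position accepts a group made of carbon only in place of one that carries nitrogen, oxygen and fluorine, with no step beyond the scatter. The shared core and the aromatic ring on this nitrogen stay the same in the pair, and nothing shown gives a reason for the size of this step.

The compounds shown leave open whether this position would hold its reading without an aromatic ring, for example with a plain hexyl chain on the nitrogen. They also leave open what a primary amine or a carboxylic acid on the phenyl ring would do in this same place.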